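Capping the hydroxy group of compound 2

The compounds below may be only part of what the source reports. "The series", "measured", "known", "first", "only" and "open" are said of these compounds alone.

In an ADME assay on Vero cells (Chlorocebus sabaeus) for cytotoxicity, read by resazurin assay, with a stated time of 72 h (on this read-out higher numbers stand for lower toxicity in this test and lower numbers for higher toxicity in this test), compound 2 (`C#CCOc1ccc(C(=O)/C=C/c2cccnc2)c(O)c1`) gives 40000 nM as the lowest of three numbers. Compound 3 (`C#CCOc1ccc(C(=O)/C=C/c2ccc(Br)cc2)c(OC)c1`) gives 100000 nM in the same test, and compound 1 (`CC(C)=CCOc1ccc(C(=O)/C=C/c2cccnc2)c(O)c1`) gives 210000 nM as the highest. Compound 4 (`C#CCOc1ccc(C(=O)/C=C/c2cccnc2)c(OCC#C)c1`) carries propargyl in place of hydrogen on an oxygen on an aromatic ring, turning hydroxy into propargyloxy (propargyl in place of hydrogen on an oxygen on an aromatic ring). Among the compounds with values here, no measured step covers this change. Within the data shown here, the only guide to size is the modest 5.3-fold lower number from compound 1 to compound 2 (0.72 log units; beyond the scatter) at another place. Since compound 2 stands lowest at 40000 nM there, a modest rise is expected. The expected change is a 2.3-fold higher number from compound 2 to compound 4 (0.35 log units; beyond the scatter) in all. For compound 4, the estimate is 90000 nM within a range of 30000 nM to 250000 nM in this assay when measured.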

Compound 4, half-maximal cytotoxic concentration: 6000 nM
Estimate against measurement, compound 4: 15-fold (1.18 log units) above; the measured number lies below the stated range.
By their numbers in this assay, from the lowest: compound 4; then compound 2; then compound 3; then compound 1.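

In this assay, propargyl in place of hydrogen on an oxygen on an aromatic ring gives a 6.7-fold lower number from compound 2 to compound 4 (0.82 log units; beyond the scatter), a step beyond the scatter towards higher toxicity in this test. Within the data shown here, the earlier step changed the other ether chain, so this is the first evidence that the hydroxy position also moves the number. It does so in the same downward direction, leaving compound 4 lowest of the four.

As far as these compounds go, whether a longer chain or a carboxylic acid on this oxygen would lower the number as well remains open. Nothing available here gives a reason for the drop.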